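This account rests on a few compounds, and the source may have more. Where it says the series, first, only, none or still open, it means among the compounds named here.

Working notes on the series.

Of the compounds shown here, three of the shared core have been measured in an ADME assay on MT4 cells (Homo sapiens) for cytotoxicity, read by MTT assay, with a stated time of 5 days; a lower number here means that less compound is tolerated, a higher number that more compound is tolerated. Compound 1 `COc1cc(Cc2cnc(/N=C3\C(=O)N(CN4CCN(Cc5ccccc5)CC4)c4ccc(Cl)cc43)nc2N)cc(OC)c1OC` gives 36.1 ug/mL. Compound 2 `COc1cc(Cc2cnc(/N=C3\C(=O)N(CN(Cc4ccccc4)Cc4ccccc4)c4ccc(Cl)cc43)nc2N)cc(OC)c1OC` gives 44.1 ug/mL, and compound 3 `CCCCN(CCCC)CN1C(=O)/C(=N\c2ncc(Cc3cc(OC)c(OC)c(OC)c3)c(N)n2)c2cc(Cl)ccc21` gives 62.6 ug/mL. The three numbers sit close together; the spread from compound 1 to compound 2 and from compound 1 to compound 3 stays within the usual scatter of this assay, so the three compounds cannot be separated on cytotoxicity with the data at hand.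

Compound 4 `COc1cc(Cc2cnc(/N=C3\C(=O)N(CN4CCN(c5ccc(Cl)cc5)CC4)c4ccc(Cl)cc43)nc2N)cc(OC)c1OC` has not yet been measured in this assay. It differs from compound 1 in one place: 4-chlorophenyl in place of benzyl on an amine nitrogen in a ring. Among the compounds with values here, no measured pair in the set isolates this kind of change, so there is no step to lean on; the only guide is that the three measured variations of the group on the amide nitrogen have not moved the half-maximal cytotoxic concentration beyond the scatter.

On that basis compound 4 is expected to come out near compound 1, with a step from compound 1 to compound 4 of a 1.0-fold lower number from compound 1 to compound 4 (0.01 log units; within the scatter) that is not expected to exceed the scatter in either direction. The estimate for compound 4 in this assay is 35 ug/mL, with a range from 18 ug/mL to 70 ug/mL.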

Compound 4, half-maximal cytotoxic concentration: 38.6 ug/mL
Compound 4: the middle estimate sits 1.1-fold (0.04 log units) below what was measured; measured number inside the range.
By their numbers in this assay, from the lowest: compounds 1, 4, 2 and 3 (each within the scatter of the next).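

In this assay, within the data shown here, the exchange of benzyl for 4-chlorophenyl on an amine nitrogen in a ring gives a 1.1-fold higher number from compound 1 to compound 4 (0.03 log units; within the scatter) and is the first step that isolates a single change at this position. The opening compounds varied the whole group on the amide nitrogen, whereas this pair shows that, with the six-membered non-aromatic ring with 2 nitrogen kept, exchanging one of these aromatic groups for the other does not separate the two compounds on cytotoxicity, so this position tolerates the change within the scatter. No measurement at hand offers an explanation for this result.

The step combines two differences, the loss of the carbon link of benzyl and the entry of chlorine on the aromatic ring, and a plain phenyl group at this place would be needed to tell them apart. On these data alone, it also remains open whether the half-maximal cytotoxic concentration would stay this flat with a group of a different kind on this nitrogen, such as a carboxylic acid, a free amine or a longer alkyl chain.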